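A few compounds are considered here, and "the series" means these few. Any claim that something is new, unique, unknown or untested is made for them only; others in the source may bear on it.

Compound 1 `COc1cc(-c2nc(SCc3cn(CC(=O)NC(=O)Nc4ccccn4)nn3)nc(Nc3ccc(C(C)C)cc3)c2C#N)cc(OC)c1OC` gives 30900 nM in a functional assay on MCF7 cells (Homo sapiens) for inhibition, read by MTT assay, with a stated time of 72 h; a lower number here means a stronger inhibitor, a higher number a weaker inhibitor.
Compound 2 `CC(C)c1ccc(Nc2nc(SCc3cn(CC(=O)NC(=O)Nc4ccccn4)nn3)nc(-c3ccc(Br)cc3)c2C#N)cc1` gives 30600 nM in this assay.

Compound 2 stands alongside compound 1: the step of a 1.0-fold lower number from compound 1 to compound 2 (0.00 log units; within the scatter) shows the two within the scatter of each other, even though that step swapped one whole aromatic group for another. Compound 3 `CC(C)c1ccc(Nc2nc(SCc3cn(CC(=O)NC(=O)Nc4ccccn4)nn3)nc(-c3ccc(Cl)cc3)c2C#N)cc1` differs from compound 2 by a smaller change: chloro in place of bromo on an aromatic carbon. Within the data shown here, no measured step tests this halogen swap directly, but because the far larger change of a 1.0-fold lower number from compound 1 to compound 2 (0.00 log units; within the scatter) left the number unchanged, no step beyond the scatter is expected here. For compound 3 the expected step is a 1.0-fold lower number from compound 2 to compound 3 (0.01 log units; within the scatter), giving an estimate of 30000 nM, within 12000 nM to 75000 nM.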

Compound 3, half-maximal inhibitory concentration: 39900 nM
For compound 3 the middle estimate is 1.3-fold (0.12 log units) below the measured one; the measured number falls inside the stated range.
By their numbers in this assay, from the lowest: compounds 2, 1 and 3 (each within the scatter of the next).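

In this assay, the halogen swap on this aromatic carbon now has its own reading: chloro in place of bromo stays within the scatter (a 1.3-fold higher number from compound 2 to compound 3 (0.12 log units; within the scatter)). The 4-chlorophenyl group also matches the 3,4,5-trimethoxyphenyl group (a 1.3-fold higher number from compound 1 to compound 3 (0.11 log units; within the scatter)), so all three groups at this position read alike. No measured evidence offers an explanation for this.

The compounds shown leave open whether any group here can move the number beyond the scatter. An amine or a carboxylic acid on this ring would be one such test.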